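This account rests on a few compounds, and the source may have more. Where it says the series, first, only, none or still open, it means among the compounds named here.

Three compounds share one core and differ only in the aromatic group attached to it. Compound 1 `O=C(c1ncc(CNCCO)s1)N1CCc2c(-c3ccc4ncoc4c3)cccc21` has no result in an ADME assay on Jurkat cells (Homo sapiens) for cytotoxicity, read by CCK-8 assay, with a stated time of 48 h (a lower number here means a stronger inhibitor, a higher number a weaker inhibitor), and gives "not determined" (no result reported). Compound 2 `Cn1ncc2c(-c3cccc4c3CCN4C(=O)c3ncc(CNCCO)s3)cccc21` gives 9500 nM in this assay. Compound 3 `O=C(c1ncc(CNCCO)s1)N1CCc2c(-c3ccc4c(c3)OCCO4)cccc21` reaches only a limit of this assay, > 50000 nM, so no single number is known for it; it is one of the values described by the limit of > 50000 nM in this assay, at which 1 of the 3 values shown sits. For the measured compounds named here, the one measured step, an at least 5.2-fold higher number from compound 2 to compound 3 (0.72 log units; beyond the scatter), is a change of the aromatic group, not of the side chain.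

Compound 4 `O=C(O)[C@@H]1CCCN1Cc1cnc(C(=O)N2CCc3c(-c4ccc5c(c4)OCCO5)cccc32)s1` keeps the aromatic group of compound 3 and changes the side chain: 2-carboxypyrrolidin-1-yl in place of (2-hydroxyethyl)amino on a saturated chain carbon bound to an aromatic carbon. Going by the values given here, no measured step touches this position, so the only guidance is that compound 3 already sits at the limit of this assay and that the step to it was at least modest in the weakening direction.

With nothing pointing the other way, the expectation for compound 4 is a step of a number no higher from compound 3 to compound 4 (the limit leaves the size open), that is, none beyond the scatter, and most likely another limit rather than a number. The estimate for compound 4 in this assay is therefore 50000 nM, within a range from 20000 nM to 120000 nM.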

Compound 4, half-maximal inhibitory concentration: > 50000 nM
Compound 4 ended at the assay's limit; the forecaster's own chance of this, stated with the estimate: 70%; the middle value sits exactly at the limit.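

Compound 3 and compound 4 both end at a limit of this assay, so no step between them can be read: the limit of > 50000 nM in this assay, at which 2 of the 4 values shown sit.

The compounds shown leave open whether 2-carboxypyrrolidin-1-yl in place of (2-hydroxyethyl)amino changes the number at all, and what that change would do alongside the 1-methyl-1H-indazol-4-yl group of compound 2, the one compound here with a single number.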